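The compounds below may be only part of what the source reports. "The series", "measured", "known", "first", "only" and "open" are said of these compounds alone.

In a functional assay on a cell-free system (Platelet, plasma, Homo sapiens) for inhibition, read by turbidimetry, with a stated time of 3 min (on this read-out lower numbers stand for stronger inhibition and higher numbers for weaker inhibition), compound 1 `COc1ccc(-n2nc(C(=O)N3CCCCC3)cc2-c2ccc(Cl)cc2)nn1` gives 41 nM, and compound 2 `CS(=O)(=O)c1ccc(-n2nc(C(=O)N3CCCCC3)cc2-c2ccc(Cl)cc2)nn1` gives 19600 nM, the higher of the two exact numbers. Compound 3 `CS(=O)(=O)c1ccc(-n2nc(C(=O)N3CCOCC3)cc2-c2ccc(Cl)cc2)nn1` reaches only a limit of the assay, > 20000 nM.

Compound 4 `O=C(c1cc(-c2ccc(Cl)cc2)n(-c2ccc(=O)[nH]n2)n1)N1CCCCC1` keeps the 4-chlorophenyl group and the (piperidin-1-yl)carbonyl group of compound 2 but exchanges the group on the aromatic nitrogen: a group of 7 heavy atoms (4 carbon, 2 nitrogen, 1 oxygen; one six-membered aromatic ring with 2 hetero atoms) in place of a group of 10 heavy atoms (5 carbon, 2 nitrogen, 2 oxygen, 1 sulfur; one six-membered aromatic ring with 2 hetero atoms), on an aromatic nitrogen. The entering group brings a hydrogen-bond donor, and the leaving group has none.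

The most relevant measurement comes from the same six-membered aromatic ring, where methylsulfonyl in place of methoxy gave a 480-fold higher number from compound 1 to compound 2 (2.68 log units; beyond the scatter). That large step shows how far a change on this ring can move the number. The other measured step, an at least 1.0-fold higher number from compound 2 to compound 3 (0.00 log units; that floor lies within the scatter), swaps piperidin-1-yl for morpholin-4-yl, a change that compound 4 does not make, so it offers little guidance.

Compound 4 lacks the methylsulfonyl group of compound 2 but does not regain the methoxy group of compound 1, so a partial recovery is expected. The expected change is a 9.8-fold lower number from compound 2 to compound 4 (0.99 log units; beyond the scatter), a clear move to a lower number but well short of the full gap. For compound 4 the estimate is 2000 nM, with an expected range from 200 nM to 20000 nM.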

Compound 4, half-maximal inhibitory concentration: 2090 nM
Beside the measured number, compound 4's estimate is 1.0-fold (0.02 log units) below it; measured number inside the range.
By their numbers in this assay, from the lowest: compound 1; then compound 4; then compound 2. At a limit, above all of these: compound 3.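

In this assay, exchanging the 6-(methylsulfonyl)pyridazin-3-yl group on the aromatic nitrogen for the group of compound 4 gives a 9.4-fold lower number from compound 2 to compound 4 (0.97 log units; beyond the scatter) and so recovers part of the number lost with the methylsulfonyl group, even though no methoxy group returns. The distance still left is a 51-fold higher number from compound 1 to compound 4 (1.71 log units; beyond the scatter) and it shows that the group of compound 4 does not match the methoxy-bearing group of compound 1. For the compounds shown here, the earlier compounds marked only two far-apart numbers for this position, whereas compound 4 adds a point between them and shows that a group bringing a hydrogen-bond donor can sit here with a number better than that of the methylsulfonyl group, though well short of methoxy.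

As far as these compounds go, it remains open whether an ethoxy group, a dimethylamino group or a single chlorine atom on the same six-membered aromatic ring would come closer to methoxy or fall nearer to methylsulfonyl. Nothing among the measurements given explains why these three groups fall in this order.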